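The source may hold more compounds than are shown below. What is called first, only, known or untested is meant among the compounds shown, and "the series" means these compounds.

Working notes on the series, read in a functional assay on A549 cells (Homo sapiens) for antiproliferative activity, read by MTT assay, with a stated time of 72 h; a higher number here means a weaker inhibitor, a lower number a stronger inhibitor. Compound 1 `O=C(N/N=C/c1ccc(F)cc1)Nc1ccc(Oc2ccnc3[nH]ccc23)c(F)c1` gives 680 nM, compound 2 `O=C(N/N=C/c1ccc(O)cc1)Nc1ccc(Oc2ccnc3[nH]ccc23)c(F)c1` gives 3760 nM, and compound 3 `O=C(N/N=C/c1ccc(F)cc1)Nc1ccc(Oc2ccnc3[nH]ccc23)cc1` gives 1430 nM, the second highest of the three numbers. Compound 4 `O=C(N/N=C/c1ccc(O)cc1)Nc1ccc(Oc2ccnc3[nH]ccc23)cc1` departs from compound 3 at one place: hydroxy in place of fluoro on an aromatic carbon. This is 4-fluorophenyl to 4-hydroxyphenyl, on the ring that also carries the hydrazone-side substituent of the shared core in the drawing of compound 4.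

The direct precedent is the same hydroxy in place of fluoro on an aromatic carbon, a 5.5-fold higher number from compound 1 to compound 2 (0.74 log units; beyond the scatter), a modest step beyond the scatter towards a weaker number. The other measured step, a 2.1-fold higher number from compound 1 to compound 3 (0.32 log units; beyond the scatter), is a change elsewhere in the molecule and sets only the starting point. Whether the first step carries over to a compound without that other fluoro has not been measured. A modest rise of similar size is therefore expected, with some allowance for a smaller one: a 4.9-fold higher number from compound 3 to compound 4 (0.69 log units; beyond the scatter) is the estimated step. For compound 4 the expected value in this assay is 7000 nM, with an estimated range of 3200 nM to 15000 nM.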

Compound 4, half-maximal inhibitory concentration: 1910 nM
Compound 4: the middle estimate sits 3.7-fold (0.56 log units) above what was measured, outside the stated range (below it).
By their numbers in this assay, from the lowest: compound 1; then compounds 3, 4 and 2 (each within the scatter of the next, the first and the last beyond it).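

Hydroxy in place of fluoro on this aromatic carbon does not have a fixed effect in this assay: a 1.3-fold higher number from compound 3 to compound 4 (0.13 log units; within the scatter) is within the scatter, and the step depends on the core that carries it: the same change on two cores in this assay, a 5.5-fold higher number (0.74 log units; beyond the scatter) from compound 1 to compound 2 and a 1.3-fold higher number (0.13 log units; within the scatter) from compound 3 to compound 4, 4.1-fold (0.62 log units) apart, beyond the scatter of two such steps. Read from the other side of the same four compounds, hydrogen in place of fluoro on the shared core gives a 2.0-fold lower number from compound 2 to compound 4 (0.29 log units; within the scatter), also within the scatter, and this differs from the step between the two 4-fluorophenyl compounds: the same change on two cores in this assay, a 2.1-fold higher number (0.32 log units; beyond the scatter) from compound 1 to compound 3 and a 2.0-fold lower number (0.29 log units; within the scatter) from compound 2 to compound 4, 4.1-fold (0.62 log units) apart, beyond the scatter of two such steps. The two changes therefore do not add across these four compounds.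

Open, going by these compounds, is whether an amine or a methoxy group on the same aromatic carbon would show the same dependence on the core. These values also cannot tell why the step differs between the two cores.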